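Aryl ether variation on a thiazolidinedione agonist series

A few compounds are considered here, and "the series" means these few. Any claim that something is new, unique, unknown or untested is made for them only; others in the source may bear on it.

Measured so far:
Compound 1 `Cc1ccc(C)c(Oc2ccc(CC3SC(=O)NC3=O)cc2)c1` — 238 nM
Compound 2 `Cc1ccnc(Oc2ccc(CC3SC(=O)NC3=O)cc2)c1` — 4280 nM
Compound 3 `O=C1NC(=O)C(Cc2ccc(Oc3ccc(Cl)cc3)cc2)S1` — 240 nM

In a functional assay for agonist activity at Free fatty acid receptor 1 (Homo sapiens), read by FLIPR, in the presence of a further agent that is not named here (on this read-out higher numbers stand for an effect only at larger amounts of compound and lower numbers for an effect already at smaller amounts), compound 3 gives 240 nM, the second highest of the three numbers. Its nearest neighbour is compound 1, whose value in this assay is 238 nM, a difference within the scatter, so no order can be drawn between the two. Compound 2 stands furthest away at 4280 nM, and the step of an 18-fold lower number from compound 2 to compound 3 (1.25 log units; beyond the scatter) is the only one measured that bears on the aryl ether group.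

Compound 4 `Cc1ccccc1Oc1ccc(CC2SC(=O)NC2=O)cc1` is not yet measured. Its structural change from compound 3 is 2-methylphenyl in place of 4-chlorophenyl on an oxygen on an aromatic ring. Compound 1 shows that an all-carbon aromatic ring with methyl substitution at this position gives a value close to that of compound 3, whereas the large step of an 18-fold lower number from compound 2 to compound 3 (1.25 log units; beyond the scatter) involved a ring with a nitrogen. For compound 4 the account therefore expects a step of a 1.3-fold higher number from compound 3 to compound 4 (0.10 log units; within the scatter) within the scatter, and an estimated value of 300 nM with a range from 100 nM to 900 nM.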

Compound 4, half-maximal effective concentration: 124 nM
The estimate for compound 4 lay 2.4-fold (0.38 log units) above the measured number, and the stated range covers the measured number.
By their numbers in this assay, from the lowest: compounds 4, 1 and 3 (each within the scatter of the next); then compound 2.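

In this assay, 2-methylphenyl in place of 4-chlorophenyl on this oxygen gives a 1.9-fold lower number from compound 3 to compound 4 (0.29 log units; within the scatter) and leaves compound 3 and compound 4 unordered, while hydrogen in place of methyl on an aromatic carbon gives a 1.9-fold lower number from compound 1 to compound 4 (0.28 log units; within the scatter) and likewise separates nothing. Compound 1, compound 3 and compound 4 thus form a group of three all-carbon aryl ethers with different substituents, and the ring with a nitrogen stands apart, now also through a second large step (a 35-fold lower number from compound 2 to compound 4 (1.54 log units; beyond the scatter)). Nothing measured here gives a reason for this difference.

With only compound 2 carrying a ring nitrogen, the effect of that nitrogen cannot be separated from that of where its methyl sits. Going by these compounds, whether a methoxy or trifluoromethyl group on the phenyl ring would stay with this group also remains open.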